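A few compounds are considered here, and "the series" means these few. Any claim that something is new, unique, unknown or untested is made for them only; others in the source may bear on it.

Values in a functional assay on HepG2 cells (Homo sapiens) for antiproliferative activity, read by MTT assay, with a stated time of 48 h; a higher number here means a weaker inhibitor, a lower number a stronger inhibitor:
Compound 1 `CC(=O)N1N=C(c2ccc3ccccc3c2)OC1c1ccc(F)cc1`: 1.82 ug/mL
Compound 2 `CC(=O)N1N=C(c2ccc3ccccc3c2)OC1c1ccc([N+](=O)[O-])cc1`: 8.1 ug/mL
Compound 3 `CC(=O)N1N=C(c2ccc3ccccc3c2)OC1c1ccc2ccccc2c1`: 0.85 ug/mL

Compound 1 holds the second highest of the three numbers. Next for testing is compound 4 `CC(=O)N1N=C(c2ccc3ccccc3c2)OC1c1ccncc1`, with pyridin-4-yl in place of 4-fluorophenyl on a saturated ring carbon. The nearest measured step is a 4.5-fold higher number from compound 1 to compound 2 (0.65 log units; beyond the scatter), a nitro in place of fluoro on an aromatic carbon. It is modest and beyond the scatter, but it leaves the carbon-only ring intact, so it is only a loose guide. Compound 3 at 0.85 ug/mL shows that a change at this carbon can also give a lower number. A modest step toward a higher number is expected in this assay. The expected step is a 1.9-fold higher number from compound 1 to compound 4 (0.28 log units; within the scatter). For compound 4 the estimated value is 3.5 ug/mL, with an expected range of 1.2 ug/mL to 10 ug/mL.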

Compound 4, half-maximal inhibitory concentration: 2.17 ug/mL
Compound 4: middle estimate off by 1.6-fold (0.21 log units), on the high side; low and high end bracket the measured number.
By their numbers in this assay, from the lowest: compound 3; then compounds 1 and 4 (each within the scatter of the next); then compound 2.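

In this assay the saturated ring carbon takes pyridin-4-yl in place of 4-fluorophenyl, with a 1.2-fold higher number from compound 1 to compound 4 (0.08 log units; within the scatter) and thus no step beyond the scatter. Replacing 4-nitrophenyl with the same group gives a 3.7-fold lower number from compound 2 to compound 4 (0.57 log units; beyond the scatter) here, so the higher number of compound 2 does not extend to this replacement. No measurement on hand explains either step.

Whether the place of the ring nitrogen matters stays open, as pyridin-3-yl is not among the compounds shown. As far as these compounds go, a saturated amine such as piperidin-4-yl at this carbon also remains untested in this set.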